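The compounds below may be only part of what the source reports. "The series", "measured", "known", "first", "only" and "open" are said of these compounds alone.

This study concerns inhibitors of one receptor, and the measure throughout is an assay on cells for displacement of a labelled ligand from corticotropin-releasing factor receptor 1 (Homo sapiens), with a stated time of 100 min; a higher number here means a weaker inhibitor, a lower number a stronger inhibitor. Of the compounds shown here, three have been measured so far. Compound 1 `CCCN(CC1CC1)C(=O)c1c(C)nc2n(-c3c(C)cc(C)cc3C)c(Cl)cn12` gives 61 nM in this assay. Compound 2 `Cc1cc(C)c(-n2c(Cl)cn3c(CN(CCC(F)(F)F)CC4CC4)c(C(F)(F)F)nc23)c(C)c1` gives 16 nM, the lowest number of the three and therefore the strongest inhibitor here, since its gap to each of the other two lies beyond the usual scatter. Compound 3 `Cc1cc(C)c(-n2c(Cl)cn3c(CN4CCCC4Cc4ccccc4)c(C(F)(F)F)nc23)c(C)c1` gives 190 nM, the highest number of the three.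

Compound 4 `Cc1cc(C)c(-n2c(Cl)cn3c(CN4CCC(C)CC4)c(C(F)(F)F)nc23)c(C)c1` has not yet been measured. It differs from compound 2 in one place: 4-methylpiperidin-1-yl in place of (cyclopropylmethyl)(3,3,3-trifluoropropyl)amino on a saturated chain carbon bound to an aromatic carbon. Among the measured compounds, compound 3 also carries a ring-closed amine at that kind of position, and its number is well above that of compound 2, while the open-chain amine of compound 2 gives the lowest number. On that basis the estimated step of a 3.8-fold higher number from compound 2 to compound 4 (0.57 log units; beyond the scatter) is expected to be a weakening of moderate size, beyond the scatter. Compound 4 is therefore expected to give 60 nM, within a range from 15 nM to 250 nM.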

Compound 4, inhibition constant: 3200 nM
Compound 4: middle estimate off by 53-fold (1.73 log units), on the low side; measured number outside the range, above it.
By their numbers in this assay, from the lowest: compound 2; then compound 1; then compound 3; then compound 4.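

Replacing the open-chain (cyclopropylmethyl)(3,3,3-trifluoropropyl)amino group with 4-methylpiperidin-1-yl gives a 200-fold higher number from compound 2 to compound 4 (2.30 log units; beyond the scatter) in this assay and shows that a saturated chain carbon bound to an aromatic carbon is highly sensitive to the amine it carries. The step comes with no change in the counted hydrogen-bond donors and acceptors or in net charge, so those counts do not separate the two compounds. A ring-closed amine does not fix the number at this position either, as compound 3 gives 190 nM and compound 4 gives the higher 3200 nM in this assay.

Going by these compounds, it remains open whether a plain dipropylamino group or a morpholin-4-yl group here would stand nearer to compound 2 or to compound 4. Nothing shown gives a measured reason for the step.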